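Cyano in place of methoxy on compound 2

The source may report more compounds than this note shows. Statements on the series, on what has been measured and on what is new or still open speak of the compounds shown alone.

In a functional assay on KB cells (nasopharynx, Homo sapiens) for antiproliferative activity (on this read-out lower numbers stand for stronger inhibition and higher numbers for weaker inhibition), compound 1 `N#Cc1ccc(S(=O)(=O)Nc2cccc3cc[nH]c23)cc1` gives 8.5 ug/mL, while compound 2 `COc1ccc(S(=O)(=O)Nc2cccc3c(C#N)c[nH]c23)cc1` gives 1.4 ug/mL, the lower of the two numbers by a margin beyond the usual scatter. Compound 3 `N#Cc1ccc(S(=O)(=O)Nc2cccc3c(C#N)c[nH]c23)cc1` is compound 2 with cyano in place of methoxy on an aromatic carbon, para to a large group (cyano in place of methoxy on an aromatic carbon). Among the measured compounds shown here, no measured pair isolates this single swap, so the forecast is cautious. In this assay, the expected change is no larger than the usual scatter, with a 1.4-fold lower number from compound 2 to compound 3 (0.15 log units; within the scatter) as the estimated step. For compound 3, the estimated value is 1 ug/mL, within a range of 0.25 ug/mL to 4 ug/mL.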

Compound 3, half-maximal inhibitory concentration: 33 ug/mL
Compound 3: middle estimate off by 33-fold (1.52 log units), on the low side, and the stated range ends below it.
By their numbers in this assay, from the lowest: compound 2; then compound 1; then compound 3.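

In this assay, the position para to a large group proves highly sensitive: cyano in place of methoxy there gives a 24-fold higher number from compound 2 to compound 3 (1.37 log units; beyond the scatter) and turns the lowest number into the highest. Cyano in place of hydrogen on an aromatic carbon also weakens inhibition, with a 3.9-fold higher number from compound 1 to compound 3 (0.59 log units; beyond the scatter) as a smaller step. No supporting data explain either loss. The compounds shown leave open whether methoxy itself matters at this position, or whether an amine or a longer chain such as ethoxy would keep the lower number.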